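A few compounds are considered here, and "the series" means these few. Any claim that something is new, unique, unknown or untested is made for them only; others in the source may bear on it.

Compound 2 `COC(=O)c1c(Nc2ccccc2)sc(C(=O)c2ccc(C)cc2)c1C` and compound 1 `COC(=O)c1c(Nc2ccccc2)sc(C(=O)c2ccc(OC)cc2)c1C` share one core and differ only in a group on the aromatic ring of the benzoyl part. In a functional assay, with a stated time of 150 min, tested at 5 ug/mL (on this read-out higher numbers stand for a stronger effect at the one concentration tested and lower numbers for a weaker effect), compound 1 gives 13.3%, and compound 2 gives 2.08%. For the measured compounds named here, the single measured step, a number 11.2 percentage points lower from compound 1 to compound 2 (beyond the scatter), leaves compound 2 standing lowest of the two numbers, with compound 1 as its only neighbour above it.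

Compound 3 `COC(=O)c1c(Nc2ccc(F)cc2)sc(C(=O)c2ccc(C)cc2)c1C` is not yet measured. It differs from compound 2 by fluoro in place of hydrogen on an aromatic carbon. Going by the values given here, the change sits on the other aromatic ring, the one of the anilino group, while the measured step concerned the benzoyl ring, so no measured step bears directly on it. Nothing in the two measured compounds therefore speaks for a change in either direction, and a step within the scatter is the plainest expectation.

On that basis compound 3 is estimated to give 4% in this assay, within a range from -5% to 15%. This estimate means a step of a number 1.9 percentage points higher from compound 2 to compound 3 (within the scatter), expected to stay within the scatter.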

Compound 3, a percentage reported as activity, at one concentration (the size of the read-out at that concentration, not a potency): "not active" (no number reported)
For compound 3 the study gives words and no number; the estimate stays without a comparison.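

For the compounds shown here, compound 3 is reported only in words, as not active, without a number, so no step from compound 2 to compound 3 can be read. The compounds shown leave open how large any difference between compound 2 and compound 3 is, and whether one exists beyond the usual scatter. No measurement shown bears on this result.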